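Shortening the alkyl chain back toward an alkyne

This account rests on a few compounds, and the source may have more. Where it says the series, first, only, none or still open, it means among the compounds named here.

Within the data shown here, compound 3 `CCCCCCc1cn([C@H]2C[C@H](O)[C@@H](CO)O2)c(=O)[nH]c1=O` is the only member of this set with a full number: in a functional assay on L1210 cells (Mus musculus) (a higher number here means a weaker inhibitor, a lower number a stronger inhibitor), compound 3 gives 301 ug/mL. Compound 1 `O=c1[nH]c(=O)n([C@H]2C[C@H](O)[C@@H](CO)O2)cc1C#CCCO` reaches only a limit of the assay, as in this assay compound 1 gives > 1000 ug/mL. Compound 2 `CCC#Cc1cn(C2O[C@H](CO)[C@@H](O)[C@@H]2O)c(=O)[nH]c1=O` likewise stops at a limit, since in this assay compound 2 gives > 1000 ug/mL. Two of the three values therefore sit at the limit of > 1000 ug/mL in this assay, at which 2 of the 3 values shown sit, and compound 3 alone lies below it.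

Compound 4 `CC#Cc1cn([C@H]2C[C@H](O)[C@@H](CO)O2)c(=O)[nH]c1=O` has not been measured. It differs from compound 3 by prop-1-yn-1-yl in place of hexyl on an aromatic carbon. Among the measured compounds shown here, the one measured step that bears on this change is an at least 3.3-fold lower number from compound 1 to compound 3 (0.52 log units; beyond the scatter), where replacing an alkyne by hexyl brought the number down from a limit to a value. Compound 4 moves back toward an alkynyl group, so a step of about a 3.3-fold higher number from compound 3 to compound 4 (0.52 log units; beyond the scatter) upward is expected, most likely ending at a limit again. Compound 4 is expected to give 1000 ug/mL, within 400 ug/mL to 3000 ug/mL.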

Compound 4, concentration for 50% inhibition: 164 ug/mL
Compound 4: the middle estimate sits 6.1-fold (0.79 log units) above what was measured; the measured number lies below the stated range.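

At this position, on the aromatic carbon two atoms from the ring nitrogen, hexyl and prop-1-yn-1-yl cannot be told apart in this assay: the data give a 1.8-fold lower number from compound 3 to compound 4 (0.26 log units; within the scatter). The reading of compound 1 is a limit of the assay, not a number: the limit of > 1000 ug/mL in this assay, at which 2 of the 4 values shown sit. An alkyne at this position therefore does not by itself go with such a limit, since the change at the far end of the chain gives an at least 6.0-fold lower number from compound 1 to compound 4 (0.78 log units; beyond the scatter), with hydrogen in place of hydroxymethyl on a saturated chain carbon bound to a triple-bonded carbon.

The compounds shown leave open whether an amine or a methoxy group at that chain end would also stay at the limit. They also leave open whether a longer chain such as octyl would stay level with hexyl and prop-1-yn-1-yl.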